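From vinyl to cyclopropyl on a shared core

The compounds below may be only part of what the source reports. "The series", "measured", "known", "first", "only" and "open" are said of these compounds alone.

Compound 1 `CCOc1ccc(C2C(C3CC3)C(=O)N2c2cc(OC)c(OC)c(OC)c2)cc1` gives 131 nM
Compound 2 `C=CC1C(=O)N(c2cc(OC)c(OC)c(OC)c2)C1c1ccc(SCC)cc1` gives 181 nM

In a functional assay on MCF7 cells (Homo sapiens) for inhibition, read by resazurin assay, with a stated time of 72 h (on this read-out lower numbers stand for stronger inhibition and higher numbers for weaker inhibition), compound 2 gives 181 nM and compound 1 gives 131 nM (these two numbers lie within the scatter of each other). Compound 3 `CCSc1ccc(C2C(C3CC3)C(=O)N2c2cc(OC)c(OC)c(OC)c2)cc1` differs from compound 2 by having cyclopropyl in place of vinyl on a saturated ring carbon. For the measured compounds named here, no measured step shows the size of this change, so in this assay no move beyond the scatter is expected, in either direction (estimated step a 1.2-fold lower number from compound 2 to compound 3 (0.08 log units; within the scatter)). For compound 3 the estimated value is 150 nM (expected range 60 nM to 380 nM).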

Compound 3, half-maximal inhibitory concentration: 606 nM
Estimate against measurement, compound 3: 4.0-fold (0.61 log units) below, and the stated range ends below it.
By their numbers in this assay, from the lowest: compounds 1 and 2 (each within the scatter of the next); then compound 3.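

In this assay, swapping vinyl for cyclopropyl on the saturated ring carbon, a change of a single heavy atom, is enough to weaken inhibition: a 3.3-fold higher number from compound 2 to compound 3 (0.52 log units; beyond the scatter). With cyclopropyl kept in place, ethylsulfanyl in place of ethoxy on the aromatic carbon also weakens it: a 4.6-fold higher number from compound 1 to compound 3 (0.67 log units; beyond the scatter). Nothing shown here explains either step. The compounds shown leave open whether vinyl and cyclopropyl would differ as much with ethoxy on the aromatic ring. They also leave open how an amine or a longer carbon chain would fare on the saturated ring carbon.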